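This account rests on a few compounds, and the source may have more. Where it says the series, first, only, none or still open, it means among the compounds named here.

Four compounds share one core and differ only in the group attached to an aromatic carbon of that core. Compound 1 `O=C(CCCCCCc1ccccc1)c1ncc(-c2ccncn2)o1` carries a pyrimidin-4-yl group, compound 2 `O=C(CCCCCCc1ccccc1)c1ncc(-c2nnn[nH]2)o1` a 1H-tetrazol-5-yl group, compound 3 `O=C(CCCCCCc1ccccc1)c1ncc(C(=O)C(F)(F)F)o1` a (trifluoromethyl)carbonyl group, and compound 4 `O=C(CCCCCCc1ccccc1)c1ncc(-c2cc(=O)[nH]c(=O)[nH]2)o1` a six-membered ring with two hydrogen-bond donors. In an assay (Rattus norvegicus) for inhibition of Fatty-acid amide hydrolase 1 (Homo sapiens) (on this read-out lower numbers stand for stronger inhibition and higher numbers for weaker inhibition), compound 1 gives 2.3 nM, compound 2 gives 63 nM, and compound 3 gives 4 nM. Compound 3 therefore stands second highest of the three numbers, close to compound 1 and far from compound 2.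

The change to compound 4 is a group of 8 heavy atoms (4 carbon, 2 nitrogen, 2 oxygen; one six-membered aromatic ring with 2 hetero atoms) in place of a group of 6 heavy atoms (2 carbon, 1 oxygen, 3 fluorine; no ring), on an aromatic carbon. Within the data shown here, two measured steps bear on it, both swapping the same (trifluoromethyl)carbonyl against an aromatic ring: a 1.7-fold higher number from compound 1 to compound 3 (0.24 log units; within the scatter), and a 16-fold lower number from compound 2 to compound 3 (1.20 log units; beyond the scatter). The ring that lacks hydrogen-bond donors left the number almost unchanged, while the ring with a donor gave a much higher number, and the entering group of compound 4 carries two donors. On that basis a higher number beyond the scatter is expected for compound 4, estimated as 40 nM, with a range from 8 nM to 200 nM. This estimate means a step of a 10-fold higher number from compound 3 to compound 4 (1.00 log units; beyond the scatter).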

Compound 4, inhibition constant: 12 nM
Compound 4: middle estimate off by 3.3-fold (0.52 log units), on the high side, within the range that was stated.
By their numbers in this assay, from the lowest: compounds 1 and 3 (each within the scatter of the next); then compound 4; then compound 2.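

In this assay the new ring lands in the middle of the set, with a 3.0-fold higher number from compound 3 to compound 4 (0.48 log units; beyond the scatter) and a 5.2-fold higher number from compound 1 to compound 4 (0.72 log units; beyond the scatter) on one side and a 5.3-fold lower number from compound 2 to compound 4 (0.72 log units; beyond the scatter) on the other. A ring carrying hydrogen-bond donors on this aromatic carbon can therefore cost some inhibition without reaching the large loss seen with 1H-tetrazol-5-yl, so the donor count alone does not order these numbers, and compound 2 goes against such a trend. Nothing available here explains this order.

From the compounds shown here alone, whether a ring is needed at this position at all stays open, as a carboxylic acid, an amine or a nitrile on the same carbon would test that. Also open, going by these compounds, is whether a methyl group in place of each ring hydrogen on nitrogen in compound 4 would shift its number.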